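A few compounds are considered here, and "the series" means these few. Any claim that something is new, unique, unknown or untested is made for them only; others in the source may bear on it.

Measured so far:
compound 1 `FC(F)(F)c1c(CN2CCC(c3ccccc3Cl)CC2)ccn2c(CC3CC3)nnc12` gives 13.5 nM in an assay on CHO cells for positive allosteric modulation of metabotropic glutamate receptor 2 (Homo sapiens), read by scintillation counting, with a stated time of 30 min; a higher number here means that more compound is needed for the effect, a lower number that less compound is needed;
compound 2 `Fc1ccc([C@H]2CC[C@@H](NCc3ccn4c(CC5CC5)nnc4c3C(F)(F)F)CC2)c(F)c1` gives 38 nM in this assay.

Compound 2 stands at the higher of the two numbers, so it needs more compound than compound 1 for the same effect, and the gap between them is beyond the scatter of repeated measurements.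

Compound 3 `Fc1ccc([C@H]2CC[C@H](NCc3ccn4c(CC5CC5)nnc4c3C(F)(F)F)CC2)c(F)c1` has not yet been measured. Compared with compound 2, (the two compounds have the same atoms and bonds and differ only in configuration as drawn: 2 of 2 stereo elements differ (all stereocentres are inverted: mirror images); a stereocentre at a saturated ring carbon is drawn s in compound 2 and r in compound 3; a stereocentre at a saturated ring carbon is drawn s in compound 2 and r in compound 3). Nothing among the two measured compounds shows how changing the drawn configuration alone moves the read-out, so the direction of the step cannot be read from a measured pair. In such cases the number can move either way, and often by more than the scatter. The estimate for compound 3 is 60 nM with a range from 15 nM to 250 nM, which means an expected step of a 1.6-fold higher number from compound 2 to compound 3 (0.20 log units; within the scatter).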

Compound 3, half-maximal effective concentration: 83 nM
Compound 3: middle estimate off by 1.4-fold (0.14 log units), on the low side; the range from low to high includes it.
By their numbers in this assay, from the lowest: compound 1; then compound 2; then compound 3.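

In this assay, inverting both stereocentres at the saturated ring carbons gives a 2.2-fold higher number from compound 2 to compound 3 (0.34 log units; beyond the scatter), a modest move. Within the data shown here, this is the first measured pair in which atoms and bonds stay the same, so it shows that the drawn configuration at these two carbons matters for the read-out, though the effect is not large. The shift can be traced to that configuration alone because nothing else separates the pair: the fact that compounds 2 and 3 differ only in the configuration as drawn

From the compounds shown here alone, what remains open is whether inverting these stereocentres would move the number in the same direction and by a similar amount with other groups on the compound, such as a methoxy group in place of the two fluorines or an amide in place of the amine. This single pair cannot show why one configuration needs less compound than the other.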